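The source may report more compounds than this note shows. Statements on the series, on what has been measured and on what is new or still open speak of the compounds shown alone.

Working notes on the series.

Within the data shown here, compound 1, `O=C(O)c1ccc(NC(c2ccc(Br)cc2)c2ccc3ccccc3c2O)cc1`, is the only compound in the set with a measured number: in an assay on isolated protein for inhibition of CAAX prenyl protease 2 (Homo sapiens), with stated times of 60 s and 60 min (a lower number here means a stronger inhibitor, a higher number a weaker inhibitor), compound 1 gives 3900 nM. Compound 2, `N#Cc1ccc2ccc(C(Nc3ccccc3)c3ccccc3)c(O)c2n1`, belongs to the same set but in this assay compound 2 is recorded as "not determined" (no result reported), so it offers no number to compare against. With one number in hand, compound 1 can be placed neither high nor low within the series; it is simply the reference point.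

Compound 3, `O=C(O)c1ccc(NC(c2ccc3ccccc3c2O)c2c(F)cc(Br)cc2F)cc1`, has not yet been measured. It differs from compound 1 in one place: 4-bromo-2,6-difluorophenyl in place of 4-bromophenyl on a saturated chain carbon bound to an aromatic carbon and a nitrogen on an aromatic ring. Among the measured compounds shown here, no step between measured compounds is available for this kind of change, so nothing in the data shows how adding the two fluorines to that ring moves the readout. The change is small in size and leaves donors, acceptors and charge unchanged, which gives no grounds to expect a step beyond the usual scatter in either direction.

Compound 3 is therefore estimated at 3000 nM in this assay, with a range of 1000 nM to 10000 nM, the expected step being a 1.3-fold lower number from compound 1 to compound 3 (0.11 log units; within the scatter).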

Compound 3, half-maximal inhibitory concentration: 3800 nM
Estimate against measurement, compound 3: 1.3-fold (0.10 log units) below; measured number inside the range.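

In this assay, among these compounds, the exchange of 4-bromophenyl for 4-bromo-2,6-difluorophenyl, on a saturated chain carbon bound to an aromatic carbon and a nitrogen on an aromatic ring, gives a 1.0-fold lower number from compound 1 to compound 3 (0.01 log units; within the scatter) and is the first step that can be read at all. At this place, then, a ring carrying two more fluorine atoms and two more heavy atoms in total gives a read-out indistinguishable from that of the parent, so this one change neither gains nor loses anything measurable against compound 1. No measurement on hand bears on why the step is so small.

From the compounds shown here alone, what stays open is whether this place accepts groups of a different kind, such as an amine, a longer alkyl chain or a phenyl ring without the bromine, with an equally flat result, or whether the flat step holds only for this particular pair of substituted phenyl rings. Equally open, going by these compounds, is whether replacing the carboxylic acid with an amide, a change at another place on the core of compound 1, would move the read-out beyond the scatter.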